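A few compounds are considered here, and "the series" means these few. Any claim that something is new, unique, unknown or untested is made for them only; others in the source may bear on it.

Working notes on the series.

Compound 1 `COCC#Cc1cn([C@H]2C[C@H](O)[C@@H](CO)O2)c(=O)[nH]c1=O` gives 254 ug/mL in a functional assay on L1210 cells (Mus musculus) (a higher number here means a weaker inhibitor, a lower number a stronger inhibitor), the lowest of the two numbers in hand. Compound 2 `CCCC/C=C\c1cn([C@H]2C[C@H](O)[C@@H](CO)O2)c(=O)[nH]c1=O` gives 361 ug/mL in this assay, and the step of a 1.4-fold higher number from compound 1 to compound 2 (0.15 log units; within the scatter) does not separate the two. Compound 3 `O=c1[nH]c(=O)n([C@H]2C[C@H](O)[C@@H](CO)O2)cc1C#CCO` gives only a limit, > 1000 ug/mL, in this assay; this is the limit of > 1000 ug/mL in this assay, at which 1 of the 3 values shown sits. The steps of an at least 3.9-fold higher number from compound 1 to compound 3 (0.59 log units; beyond the scatter) and an at least 2.7-fold higher number from compound 2 to compound 3 (0.44 log units; beyond the scatter) both run toward weaker inhibition.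

Compound 4 `CC#CCc1cn([C@H]2C[C@H](O)[C@@H](CO)O2)c(=O)[nH]c1=O` is not yet measured. It differs from compound 1 as follows: but-2-yn-1-yl in place of 3-methoxyprop-1-yn-1-yl on an aromatic carbon. Among the measured compounds shown here, two measured steps bear on this. The change from 3-methoxyprop-1-yn-1-yl to hex-1-en-1-yl, a 1.4-fold higher number from compound 1 to compound 2 (0.15 log units; within the scatter), stayed within the scatter; the change from methyl to hydrogen on the oxygen, an at least 3.9-fold higher number from compound 1 to compound 3 (0.59 log units; beyond the scatter), gave a weaker compound. Replacing the 3-methoxyprop-1-yn-1-yl group by but-2-yn-1-yl is closer to the first of these, so no step beyond the scatter is expected, a 1.0-fold higher number from compound 1 to compound 4 (0.01 log units; within the scatter). Compound 4 is therefore estimated at 260 ug/mL in this assay, in the range 110 ug/mL to 650 ug/mL.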

Compound 4, concentration for 50% inhibition: > 1000 ug/mL
Compound 4 ended at the assay's limit (the forecaster's own chance of this, stated with the estimate: 10%); at least 3.8-fold (0.58 log units) between middle value and limit.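

Replacing 3-methoxyprop-1-yn-1-yl by but-2-yn-1-yl gives an at least 3.9-fold higher number from compound 1 to compound 4 (0.59 log units; beyond the scatter), and replacing hex-1-en-1-yl by the same group gives an at least 2.7-fold higher number from compound 2 to compound 4 (0.44 log units; beyond the scatter), so this position does not accept every change of side chain without loss in this assay. Both 3-methoxyprop-1-yn-1-yl and but-2-yn-1-yl carry one triple bond outside aromatic rings, so that feature alone does not keep the number low. The value of compound 4 is a limit, and the step involving the other limit cannot be read: the limit of > 1000 ug/mL in this assay, at which 2 of the 4 values shown sit.

The compounds shown do not separate loss of the ether oxygen from the shift of the triple bond along the chain, and a prop-1-yn-1-yl group would bear on that. Also open, on these data alone, is how a longer chain such as hex-1-yn-1-yl, or an amine at the chain end, would read here.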